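One Methyl Added to a Hydroxy Group

The source may hold more compounds than are shown below. What is called first, only, known or untested is meant among the compounds shown, and "the series" means these compounds.

In a functional assay on A549 cells (Homo sapiens) for cytotoxicity, read by sulforhodamine B assay, with a stated time of 48 h (on this read-out lower numbers stand for stronger inhibition of growth and higher numbers for weaker inhibition of growth), compound 1 `COc1cc(C(=O)c2ccc(OC)c(O)c2OC)cc(OC)c1O` gives 3470 nM, and compound 2 `COc1cc(C(=O)c2ccc3c(c2)oc(=O)n3S(C)(=O)=O)cc(OC)c1OC` gives 4680 nM. Within the data shown here, these two numbers lie within the usual scatter of each other, so they do not separate the compounds, and compound 1 stands level with the only other measured compound.

Compound 3 `COc1ccc(C(=O)c2cc(OC)c(OC)c(OC)c2)c(OC)c1O` differs from compound 1 in one place: methyl in place of hydrogen on an oxygen on an aromatic ring. In words, a methyl replaces the hydrogen on an oxygen on an aromatic ring, turning hydroxy to methoxy.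

Among the measured compounds shown here, no measured pair shows this change, so the expectation remains a judgement with wide uncertainty. A moderate move towards stronger growth inhibition is expected, with the estimated step of a 5.0-fold lower number from compound 1 to compound 3 (0.70 log units; beyond the scatter).

For compound 3, the expected value in this assay is 700 nM, with an estimated range of 90 nM to 4500 nM.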

Compound 3, concentration for 50% growth inhibition: 41.3 nM
The estimate for compound 3 lay 17-fold (1.23 log units) above the measured number; measured number below the stated range.
By their numbers in this assay, from the lowest: compound 3; then compounds 1 and 2 (each within the scatter of the next).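

In this assay, adding one methyl to an oxygen on an aromatic ring, turning hydroxy to methoxy, has a large effect on growth inhibition (an 84-fold lower number from compound 1 to compound 3 (1.92 log units; beyond the scatter)). The earlier compounds shown here sat within the scatter of each other and gave no sign that a single position could separate compounds so strongly; this position is clearly sensitive to what sits on its oxygen. No measurement shown here gives a reason for the size of this step.

Among these compounds, with only this one change at this position, it remains open whether the methyl itself matters or whether any replacement of the hydrogen would do the same. An ethoxy group or a longer chain on this oxygen, or an amine in place of the hydroxy group, could help to tell these possibilities apart.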